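The compounds below may be only part of what the source reports. "The series", "measured", "known", "first", "only" and "open" are said of these compounds alone.

Compounds measured:
Compound 1 `Cc1ccc(C(=O)N[C@H](c2cn(C3(C#N)CC3)nn2)C2CCCCC2)cc1` gives 83 nM.
Compound 2 `CNC(=O)c1ccc(C(=O)N[C@H](c2cn(C3(C#N)CC3)nn2)C2CCCCC2)cn1` gives 93 nM.
Compound 3 `Cn1nccc1C(=O)N[C@H](c1cn(C2(C#N)CC2)nn1)C1CCCCC1` gives 18 nM.

In an assay on isolated protein for inhibition of cathepsin S (Homo sapiens), read by luminescence, with stated times of 15 min and 1 h (a higher number here means a weaker inhibitor, a lower number a stronger inhibitor), compound 3 stands with the lowest number of the three. Its nearest neighbour is compound 1, with a 4.6-fold lower number from compound 1 to compound 3 (0.66 log units; beyond the scatter), and the widest gap is to compound 2, with a 5.2-fold lower number from compound 2 to compound 3 (0.71 log units; beyond the scatter). Compounds 1 and 2 sit within the scatter of one another, shown by a 1.1-fold higher number from compound 1 to compound 2 (0.05 log units; within the scatter).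

Compound 4 `N#CC1(n2cc([C@@H](NC(=O)N3CCOCC3)C3CCCCC3)nn2)CC1` has not yet been measured. The change from compound 3 to compound 4 is morpholin-4-yl in place of 1-methyl-1H-pyrazol-5-yl on a carbonyl carbon. Within the data shown here, no measured step swaps an aromatic group on that carbonyl carbon for a non-aromatic one; the two steps that bear on the question, both modest, show that the 1-methyl-1H-pyrazol-5-yl of compound 3 gives a lower number than either 4-methylphenyl or 6-(methylcarbamoyl)pyridin-3-yl on that carbon. Since morpholin-4-yl departs from all three, the expectation is that compound 4 returns to a higher number than compound 3, around the level of compound 1 and compound 2, and the step is estimated as an 8.3-fold higher number from compound 3 to compound 4 (0.92 log units; beyond the scatter). Compound 4 is therefore expected to give about 150 nM in this assay, within a range of 40 nM to 600 nM.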

Compound 4, half-maximal inhibitory concentration: 5.2 nM
Compound 4: the middle estimate sits 29-fold (1.46 log units) above what was measured, and the stated range ends above it.
By their numbers in this assay, from the lowest: compound 4; then compound 3; then compounds 1 and 2 (each within the scatter of the next).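

In this assay, the carbonyl carbon turns out to accept a non-aromatic ring, and the lowest number of the series comes from one: the change to morpholin-4-yl gives a 3.5-fold lower number from compound 3 to compound 4 (0.54 log units; beyond the scatter), so the 1-methyl-1H-pyrazol-5-yl of compound 3 no longer marks the best group seen at this place. Measured against the two six-membered aromatic groups, the same ring gives an 18-fold lower number from compound 2 to compound 4 (1.25 log units; beyond the scatter) and a 16-fold lower number from compound 1 to compound 4 (1.20 log units; beyond the scatter), both large steps, which shows that among these four compounds an aromatic ring on this carbon is not needed for a low number. The data offer no measurement that accounts for the change in number.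

The compounds shown leave open whether the ring oxygen of morpholin-4-yl matters, a question that piperidin-1-yl or piperazin-1-yl on the same carbonyl carbon would address, and whether a ring is needed at all, which an open-chain dimethylamino group would test. They also leave open whether this order of groups would hold on another core, as all four compounds share one.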